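The compounds below may be only part of what the source reports. "The series", "measured", "known", "first", "only" and "open" are said of these compounds alone.

Measured in a functional assay on KB 3-1 cells (Homo sapiens) for cytotoxicity, read by MTT assay, with a stated time of 68 h; on this read-out higher numbers stand for weaker inhibition and lower numbers for stronger inhibition:
- compound 1 `O=C(Nc1cccc(-c2ccsc2)c1)C(Cl)Cl`: > 50000 nM (a limit)
- compound 2 `CSc1cccc(-c2cc(NC(=O)C(Cl)Cl)cc(-c3cccc(SC)c3)c2)c1`: > 30000 nM (a limit)

Compound 1 stands only at a limit, > 50000 nM, and no numerical value is available for it. The same holds for compound 2, whose limit is > 30000 nM.

Compound 3 `O=C(Nc1cccc(-c2cccs2)c1)C(Cl)Cl` keeps the core of compound 1 and has thiophen-2-yl in place of thiophen-3-yl on an aromatic carbon.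

For the measured compounds named here, no measured step bears on this change. The expected shift in this assay is none beyond the scatter, with no preferred direction, and the estimated step is a number no higher from compound 1 to compound 3 (the limit leaves the size open). For compound 3 the estimate is 50000 nM, with an expected range of 20000 nM to 100000 nM.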

Compound 3, half-maximal inhibitory concentration: > 50000 nM
Compound 3 ended at the assay's limit; the forecaster's own chance of this, stated with the estimate: 65%; the middle value sits exactly at the limit.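

For the compounds shown here, compound 1 and compound 3 both stand only at a limit, so no step between them can be read. The compounds shown leave open how thiophen-2-yl and thiophen-3-yl compare on the shared core in this assay.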